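Notes on compound 4: imidazolyl in place of cyanoimino ring

This account rests on a few compounds, and the source may have more. Where it says the series, first, only, none or still open, it means among the compounds named here.

Of the compounds shown here, three of the shared core have been measured in an assay on CHO cells for displacement of a labelled ligand from prostaglandin E2 receptor EP3 subtype (Homo sapiens), read by radioligand binding; a lower number here means a stronger inhibitor, a higher number a weaker inhibitor. Compound 1 `CC(C)C(Cc1ncc[nH]1)c1ccc(-c2ccc3cccc(F)c3c2)[nH]c1=O` gives 11 nM. Compound 2 `CC(C)C(O)(C(=O)O)c1ccc(-c2ccc3ccccc3c2)[nH]c1=O` gives 544 nM. Compound 3 `CC(C)C(c1ccc(-c2ccc3cccc(F)c3c2)[nH]c1=O)N1CCN/C1=N\C#N` gives 23 nM, the second highest of the three numbers: the step of a 2.1-fold higher number from compound 1 to compound 3 (0.32 log units; beyond the scatter) puts compound 1 a little under it, while the two values of compound 2 and compound 3 show compound 2 far above it.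

Compound 4 `CC(C)C(c1ncc[nH]1)c1ccc(-c2ccc3cccc(F)c3c2)[nH]c1=O` differs from compound 3 at one place: a group of 5 heavy atoms (3 carbon, 2 nitrogen; one five-membered aromatic ring with 2 hetero atoms) in place of a group of 8 heavy atoms (4 carbon, 4 nitrogen; one five-membered non-aromatic ring with 2 hetero atoms), on a saturated chain carbon bound to an aromatic carbon and a saturated chain carbon. For the measured compounds named here, the only measured step that bears on this is a 2.1-fold higher number from compound 1 to compound 3 (0.32 log units; beyond the scatter), which exchanges the same cyclic cyanoimino group for a group built around the same five-membered aromatic ring and was modest in size. Going by the values given here, compound 1, however, carries that ring on an extra chain carbon, and no measured pair covers the loss of that carbon, so the step is read only as a rough guide.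

On that basis a modest step downward from compound 3 is expected, about a 1.3-fold lower number from compound 3 to compound 4 (0.11 log units; within the scatter), with a wide margin for the shorter link. Compound 4 is therefore estimated at 18 nM in this assay, within a range of 6 nM to 55 nM.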

Compound 4, inhibition constant: 7.3 nM
Beside the measured number, compound 4's estimate is 2.5-fold (0.39 log units) above it; the measured number falls inside the stated range.
By their numbers in this assay, from the lowest: compounds 4 and 1 (each within the scatter of the next); then compound 3; then compound 2.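

In this assay the saturated chain carbon bound to an aromatic carbon and a saturated chain carbon accepts 1H-imidazol-2-yl directly, and the exchange of the cyclic cyanoimino group for this smaller aromatic ring gives a 3.2-fold lower number from compound 3 to compound 4 (0.50 log units; beyond the scatter) in a pair that differs only at this place. The earlier compounds shown here offered no direct measure of the link between this carbon and the imidazole ring, whereas the change from (1H-imidazol-2-yl)methyl to 1H-imidazol-2-yl gives a 1.5-fold lower number from compound 1 to compound 4 (0.18 log units; within the scatter) and therefore shows no readable effect of the extra chain carbon in this pair. Nothing measured here explains either step.

From the compounds shown here alone, how a longer chain such as 2-(1H-imidazol-2-yl)ethyl, a pyridine ring or a primary amine would read at this place remains open, as does the reading of a 1-methylimidazol-2-yl group. Also open is the contribution of the fluorine on the shared core, which no single-place pair among these compounds isolates.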